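Swapping the phenol of compound 2 for a sulfonamide acid

This account rests on a few compounds, and the source may have more. Where it says the series, first, only, none or still open, it means among the compounds named here.

Measured compounds:
compound 1, `O=C(Nc1ccc(O)cc1)c1cc(NC2CCCCC2)ncn1` — "not determined" (no result reported)
compound 2, `Cc1cc(O)ccc1NC(=O)c1cc(N(CC2CC2)C2CCCCC2)ncn1` — 191 nM
compound 3, `Cc1cc2[nH]ncc2cc1NC(=O)c1cc(N(CC2CC2)C2CCCCC2)ncn1` — "not determined" (no result reported)

In a functional assay on CHO cells for agonist activity at sphingosine 1-phosphate receptor 5 (Homo sapiens), read by GTPgammaS binding, with a stated time of 60 min (on this read-out higher numbers stand for an effect only at larger amounts of compound and lower numbers for an effect already at smaller amounts), compound 2 gives 191 nM. For the measured compounds named here, compound 1 and compound 3 carry no result in this assay, so compound 2 holds the only number, and no step between two measured compounds exists to calibrate against. Compound 4, `Cc1cc(S(=O)(=O)NCCC(=O)O)ccc1NC(=O)c1cc(N(CC2CC2)C2CCCCC2)ncn1`, differs from compound 2 by (2-carboxyethyl)sulfamoyl in place of hydroxy on an aromatic carbon. With nothing measured around this change, its direction cannot be read from the data; a moderate shift, possibly beyond the scatter and more likely toward weaker than stronger, is expected. The step from compound 2 to compound 4 is estimated as a 1.7-fold higher number from compound 2 to compound 4 (0.22 log units; within the scatter). Compound 4 is expected to give 320 nM in this assay, within 60 nM to 1600 nM.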

Compound 4, half-maximal effective concentration in the sphingosine 1-phosphate receptor 5 assay: 114 nM
Estimate against measurement, compound 4: 2.8-fold (0.45 log units) above; the range from low to high includes it.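

For the compounds shown here, in the sphingosine 1-phosphate receptor 5 assay compound 2 gives 191 nM and compound 4 gives 114 nM and the exchange gives a 1.7-fold lower number from compound 2 to compound 4 (0.22 log units; within the scatter) and so provides the first step that can be read: at this aromatic carbon, para to a large group, (2-carboxyethyl)sulfamoyl stands in place of hydroxy with no change beyond the scatter. In a physicochemical assay for lipophilicity (a higher number here means a more lipophilic compound, a lower number a more polar compound), compound 2 gives 7.4 and compound 4 gives "not determined" (no result reported) and the same step cannot be read. No measured evidence bears on this result. From the compounds shown here alone, whether an unsubstituted sulfamoyl group, a longer chain or an amine would be accepted at this position remains open.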